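The compounds below may be only part of what the source reports. "The series", "measured", "known", "first", "only" and "open" are said of these compounds alone.

Compound 1 `O=C(CCCCC#Cc1ccccn1)c1ncc(-c2ccccn2)o1`: 280 nM
Compound 2 `O=C(CCCCC#Cc1cccnc1)c1ncc(-c2ccccn2)o1`: 300 nM

In an assay for inhibition of Fatty-acid amide hydrolase 1 (Rattus norvegicus) (a higher number here means a weaker inhibitor, a lower number a stronger inhibitor), compound 2 gives 300 nM. Compound 1 gives 280 nM, and the step of a 1.1-fold higher number from compound 1 to compound 2 (0.03 log units; within the scatter) lies within the scatter, so the two compounds cannot be told apart. Compound 3 `O=C(CCCCC#Cc1ccc([N+](=O)[O-])cc1)c1ncc(-c2ccccn2)o1` differs from compound 2 by 4-nitrophenyl in place of pyridin-3-yl on a triple-bonded carbon. Among the measured compounds shown here, the only measured step, a 1.1-fold higher number from compound 1 to compound 2 (0.03 log units; within the scatter), swaps one pyridinyl ring for another and shows no change; no step tests a carbon-only ring or a nitro group. Resting on that single step, compound 3 is expected to give no change at the digits printed from compound 2 to compound 3 (within the scatter), a step within the scatter. The estimate for compound 3 is 300 nM, between 100 nM and 900 nM.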

Compound 3, inhibition constant: 31 nM
Compound 3: the middle estimate sits 9.7-fold (0.99 log units) above what was measured; measured number below the stated range.
By their numbers in this assay, from the lowest: compound 3; then compounds 1 and 2 (each within the scatter of the next).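

In this assay, the group on the triple-bonded carbon proves able to shift the number, which the two pyridinyl compounds did not show: the number falls with a 9.7-fold lower number from compound 2 to compound 3 (0.99 log units; beyond the scatter) and a 9.0-fold lower number from compound 1 to compound 3 (0.96 log units; beyond the scatter) when 4-nitrophenyl takes the place of a pyridinyl ring. This single change brings in a ring of carbon only and a nitro group together, so the two cannot be separated here. No measurement at hand explains the drop.

As far as these compounds go, whether a plain phenyl ring, or one carrying an amine or a carboxylic acid instead of the nitro group, would give a similar number stays open. So does the effect of a longer chain.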